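The source may report more compounds than this note shows. Statements on the series, on what has been measured and on what is new or still open speak of the compounds shown alone.

Measured in a functional assay for inhibition of sodium/hydrogen exchanger (Oryctolagus cuniculus); a lower number here means a stronger inhibitor, a higher number a weaker inhibitor:

Compound 1 `Cc1cc(C2CCC2)c(S(C)(=O)=O)cc1C(=O)N=C(N)N` gives 8.2 nM.
Compound 2 `COc1cc(C)c(C(=O)N=C(N)N)cc1S(C)(=O)=O` gives 16 nM.
Compound 3 `Cc1cc(OC2CCCC2)c(S(C)(=O)=O)cc1C(=O)N=C(N)N` gives 27 nM.

Compound 3 has the highest number of the three, so it is the weakest inhibitor shown: a 3.3-fold higher number from compound 1 to compound 3 (0.52 log units; beyond the scatter), whereas the gap to compound 2 is small, a 1.7-fold higher number from compound 2 to compound 3 (0.23 log units; within the scatter). Compound 4 `Cc1cn(-c2cc(C)c(C(=O)N=C(N)N)cc2S(C)(=O)=O)cn1` keeps the shared core and differs from compound 3 only at one position: 4-methyl-1H-imidazol-1-yl in place of cyclopentyloxy on an aromatic carbon.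

Within the data shown here, no measured step swaps a saturated group for an aromatic ring at this position. The nearest comparisons are the replacement of cyclobutyl by methoxy, a 2.0-fold higher number from compound 1 to compound 2 (0.29 log units; within the scatter), and by cyclopentyloxy, a 3.3-fold higher number from compound 1 to compound 3 (0.52 log units; beyond the scatter). Both say that this position accepts quite different groups with only small changes in this assay. A 4-methyl-1H-imidazol-1-yl ring is a new kind of substituent here, so a step in either direction is possible; a small step toward compound 1 or compound 2 seems the most likely outcome, and a large loss is not suggested by any step. For compound 4 the expected value in this assay is 20 nM, with a range of 6 nM to 70 nM, which means an expected step of a 1.4-fold lower number from compound 3 to compound 4 (0.13 log units; within the scatter).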

Compound 4, half-maximal inhibitory concentration: 28 nM
Compound 4: the middle estimate sits 1.4-fold (0.15 log units) below what was measured; the measured number falls inside the stated range.
By their numbers in this assay, from the lowest: compounds 1, 2, 3 and 4 (each within the scatter of the next, the first and the last beyond it).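

In this assay, this position takes an aromatic ring with two nitrogens as readily as a saturated ring: putting 4-methyl-1H-imidazol-1-yl in place of cyclopentyloxy gives a 1.0-fold higher number from compound 3 to compound 4 (0.02 log units; within the scatter), so the two groups cannot be told apart here despite their different ring types. The same group in place of methoxy gives a 1.8-fold higher number from compound 2 to compound 4 (0.24 log units; within the scatter), which also stays within the scatter, whereas in place of cyclobutyl it gives a 3.4-fold higher number from compound 1 to compound 4 (0.53 log units; beyond the scatter), a modest step that sets compound 1 apart from compound 4 but leaves compound 2 as the exception among the other comparisons. Nothing measured here bears on why these groups read so alike.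

Still open, from the compounds shown here alone, is how a phenyl ring, an imidazol-1-yl ring without its methyl, or an amine would read at this position. Also open, going by these compounds, is whether a cyclopentyl group, attached through carbon rather than oxygen, would fall nearer compound 1 or compound 3.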